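A few compounds are considered here, and "the series" means these few. Any claim that something is new, unique, unknown or untested is made for them only; others in the source may bear on it.

Measured in a functional assay on SH-SY5Y cells (Homo sapiens) for antagonist activity, read by cAMP accumulation; a lower number here means a less potent compound, a higher number a more potent compound, by a factor of ten per unit of this negative logarithm:
- Compound 1 `CCCOc1ccc(Cc2ccc(NC3=NCCN3)cc2)cc1`: 8.8
- Compound 2 `CCCCOc1ccc(Cc2ccc(NC3=NCCN3)cc2)cc1`: 9
- Compound 3 `CC(C)COc1ccc(Cc2ccc(NC3=NCCN3)cc2)cc1`: 8.8

Compound 3 stands level with compound 1 and within the scatter of compound 2, showing no change at the digits printed from compound 1 to compound 3 (within the scatter) and a number 0.20 log units lower from compound 2 to compound 3 (within the scatter). Compound 4 `OCCOc1ccc(Cc2ccc(NC3=NCCN3)cc2)cc1` carries hydroxymethyl in place of isopropyl on a saturated chain carbon bound to an oxygen on an aromatic ring. The closest evidence is a number 0.20 log units lower from compound 2 to compound 3 (within the scatter), at that same place, together with a number 0.20 log units higher from compound 1 to compound 2 (within the scatter). Both steps are small, but neither brings in a hydroxymethyl, so they guide the expectation only loosely. A modest fall in this assay is expected, with a wide margin. The expected change is a number 0.50 log units lower from compound 3 to compound 4 (beyond the scatter). For compound 4 the estimated value is 8.3, within a range of 7.6 to 8.9.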

Compound 4, negative logarithm of the antagonist equilibrium constant: 8
Compound 4: the middle estimate sits 0.30 log units above what was measured, and the stated range covers the measured number.
By their numbers in this assay, from the lowest: compound 4; then compounds 1, 3 and 2 (each within the scatter of the next).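

In this assay, within the data shown here, compounds 1, 2 and 3 lay within the scatter of one another, so the chain on this oxygen had seemed to tolerate change, but 2-hydroxyethoxy is the first group here to move the number beyond the scatter. The change gives a number 0.80 log units lower from compound 3 to compound 4 (beyond the scatter) and a number 1.00 log units lower from compound 2 to compound 4 (beyond the scatter) and also a number 0.80 log units lower from compound 1 to compound 4 (beyond the scatter). Nothing available accounts for this fall.

The compounds shown leave open whether 2-methoxyethoxy, an amine or a carboxylic acid on this chain would fall as far. They also leave open whether a longer chain ending in hydroxy would match compound 4.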